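The compounds below may be only part of what the source reports. "The series", "measured", "known", "first", "only" and "open" are said of these compounds alone.

Measured so far in a functional assay on HCT-116 cells (Homo sapiens) for antiproliferative activity, read by MTT assay, with a stated time of 48 h; on this read-out higher numbers stand for weaker inhibition and lower numbers for stronger inhibition:
compound 1 `CCCCCC(CCO)n1cnc2c(Cl)ncnc21` gives > 50000 nM, which is a limit of the assay.
compound 2 `CCCCCC(CCO)n1cnc2cncnc21` gives > 50000 nM, which is a limit of the assay.
compound 3 `CCCCCCCCC(CCO)n1cnc2c(N)ncnc21` gives 11600 nM.

Within the data shown here, compound 3 is the only one with a number; the other two values sit at the limit of > 50000 nM in this assay, at which 2 of the 3 values shown sit. The step from compound 2 to compound 1 is a step that the two limits leave unreadable from compound 2 to compound 1 and consists of chloro in place of hydrogen on an aromatic carbon. The difference between the cores of compound 2 and compound 3 is not broken down here. Compound 4 `CCCCCCCCC(CCO)n1cnc2c(N)nc(Cl)nc21` differs from compound 3 by chloro in place of hydrogen on an aromatic carbon, the same kind of change, though its place differs: between two ring nitrogen atoms, meta to an amino group and para to a fused ring rather than next to the ring nitrogen and ortho to a fused ring. With the measured step unreadable, the expected step from compound 3 to compound 4 is a 1.5-fold lower number from compound 3 to compound 4 (0.16 log units; within the scatter), resting only on compound 3 at 11600 nM. Compound 4 is thus estimated at 8000 nM, between 2000 nM and 40000 nM.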

Compound 4, half-maximal inhibitory concentration: 21000 nM
Beside the measured number, compound 4's estimate is 2.6-fold (0.42 log units) below it, and the stated range covers the measured number.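

In this assay, chloro in place of hydrogen on an aromatic carbon gives a 1.8-fold higher number from compound 3 to compound 4 (0.26 log units; within the scatter), so on the core of compound 3 this change cannot be told apart from the usual scatter of repeated measurements. The same change on the core of compound 2 cannot be read, because compound 1 and compound 2 each stand at a limit of the assay rather than at a number: the limit of > 50000 nM in this assay, at which 2 of the 4 values shown sit. From the compounds shown here alone, whether the change carries from one core to the other therefore stays untested, and the chloro also sits at a different place in the two pairs.

The compounds shown leave open how a nitrile or a carboxylic acid would read at the aromatic carbon between two ring nitrogen atoms, where only hydrogen and chloro appear. They also leave open whether a longer chain would shift the number on the core of compound 3.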